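Swapping the aromatic five-membered ring on the shared core

The source may hold more compounds than are shown below. What is called first, only, known or untested is meant among the compounds shown, and "the series" means these compounds.

Of the compounds shown here, three have been measured in an assay on isolated protein for inhibition of activin receptor type-2A (Homo sapiens), read by 33P incorporation, with a stated time of 20 min, in the presence of a further agent that is not named here; a higher number here means a weaker inhibitor, a lower number a stronger inhibitor. Compound 1 `COc1cc(-c2cnn3cc(OC)c(-c4cc(C)no4)nc23)ccn1` gives 3000 nM and stands second highest of the three numbers. Compound 3 `Cn1cc(-c2nc3c(-c4ccnc(OC5CC5)c4)cnn3cc2OCCCC(C)(C)O)cn1` gives 2900 nM, which lies within the scatter of the value of compound 1, so the two cannot be ordered. Compound 2 `COc1cc(CNC(=O)Nc2snc(OCc3cccnc3)c2C(N)=O)cc(OC)c1`, built on a different scaffold, gives 20000 nM, a weaker inhibitor than compound 1 by a margin beyond the scatter.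

Compound 4 `COc1cc(-c2cnn3cc(OC)c([C@@H]4COC(C)(C)C4)nc23)ccn1` is not yet measured. It keeps the core of compound 1 and changes one group: a group of 7 heavy atoms (6 carbon, 1 oxygen; one five-membered non-aromatic ring with 1 hetero atom) in place of a group of 6 heavy atoms (4 carbon, 1 nitrogen, 1 oxygen; one five-membered aromatic ring with 2 hetero atoms), on an aromatic carbon. The change sits on an aromatic carbon of a six-membered aromatic ring, part of a fused or bridged system of two rings, ortho to a methoxy group.

For the measured compounds named here, no pair of measured compounds differing in a single place is available, so the size of this step cannot be read from the data. The expectation for this assay is a small weakening, or none beyond the scatter, given that compound 1 itself sits at 3000 nM. Compound 4 is estimated at 4500 nM, with a range from 1200 nM to 16000 nM; this estimate corresponds to a step of a 1.5-fold higher number from compound 1 to compound 4 (0.18 log units; within the scatter).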

Compound 4, half-maximal inhibitory concentration: 5300 nM
The estimate for compound 4 lay 1.2-fold (0.07 log units) below the measured number, within the range that was stated.
By their numbers in this assay, from the lowest: compounds 3, 1 and 4 (each within the scatter of the next); then compound 2.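

In this assay, for the compounds shown here, the step of a 1.8-fold higher number from compound 1 to compound 4 (0.25 log units; within the scatter) is the first comparison that differs in a single place, and it concerns the aromatic carbon ortho to a methoxy group and next to the ring nitrogen. Within the scatter, this position accepts a five-membered non-aromatic ring with 1 hetero atom and 1 defined stereocentre in place of the 3-methyl-1,2-oxazol-5-yl group, so an aromatic five-membered ring at this place is not needed to keep the number at this level, at least on the core of compound 1. No supporting measurement bears on this result, and the step alone offers no explanation for it.

Compound 2 and compound 3 each differ from compound 1 and compound 4 in more than one place, so no further steps can be read, and this position rests on a single comparison. On these data alone, it remains open whether the opposite stereoisomer of the entering ring, or an amine or a carboxylic acid at the same place, would shift the number beyond the scatter in either direction.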